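The source may report more compounds than this note shows. Statements on the series, on what has been measured and on what is new or still open speak of the compounds shown alone.

Compound 1, `COc1cccc2cc(C(=O)NCC(=O)O)c(=O)oc12`: 15%
Compound 2, `COc1cccc2cc(C(=O)N[C@@H](CO)C(=O)O)c(=O)oc12`: 3%
Compound 3, `COc1cccc2cc(C(=O)NCC(O)CO)c(=O)oc12`: 1%

These three compounds were measured in an assay on HeLa cells for displacement of a labelled ligand from adenosine receptor A3 (Homo sapiens), read by scintillation counting, with a stated time of 180 min, tested at 10 uM; a higher number here means more inhibition at the concentration tested (going by the name of the read-out), a lower number less inhibition. Compound 4, `COc1cccc2cc(C(=O)NCCO)c(=O)oc12`, has not yet been measured there. Compound 4 differs from compound 3 by hydrogen in place of hydroxymethyl on a saturated chain carbon bound to an oxygen on a saturated carbon and a saturated chain carbon. The same kind of change is found in a measured pair, where compound 1 differs from compound 2 by hydrogen in place of hydroxymethyl on a saturated chain carbon bound to an amide-type nitrogen and a carbonyl carbon, and that step gave a number 12 percentage points higher from compound 2 to compound 1 (beyond the scatter). The two changes are of the same kind and not the same, as the place is not identical: in the measured pair the carbon is bound to an amide-type nitrogen and a carbonyl carbon, whereas in compound 3 it is bound to an oxygen on a saturated carbon and a saturated chain carbon. The cores of the two pairs also differ: compound 3 differs from compound 2 by 2,3-dihydroxypropyl in place of 1-carboxy-2-hydroxyethyl on an amide-type nitrogen, a pair showing a number 2 percentage points lower from compound 2 to compound 3 (within the scatter). Among the measured compounds there is also a number 14 percentage points lower from compound 1 to compound 3 (beyond the scatter). Given the rise recorded in a number 12 percentage points higher from compound 2 to compound 1 (beyond the scatter), compound 4 is expected to show a number 7 percentage points higher from compound 3 to compound 4 (within the scatter). A smaller step is expected, the surroundings of the changed carbon being unlike those of the measured pair. Compound 4 is thus estimated at 8%, with a range from -5% to 22%.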

Compound 4, a percentage reported as inhibition, at one concentration (the size of the read-out at that concentration, not a potency): 1%
The estimate for compound 4 lay 7 percentage points above the measured number; the measured number falls inside the stated range.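

In this assay, hydrogen in place of hydroxymethyl gave no change at the digits printed from compound 3 to compound 4 (within the scatter), and this step cannot be told apart from the earlier one on the other core: the same change on two cores in this assay, a number 12 percentage points higher (beyond the scatter) from compound 2 to compound 1 and no change at the digits printed (within the scatter) from compound 3 to compound 4, 12 percentage points apart, within the scatter of two such steps. This shows no measurable dependence of the change on the core across these two pairs, but it does not show that the change carries over unaltered, as two pairs at a single concentration are too few to establish that. Replacing carboxy gave a number 14 percentage points lower from compound 1 to compound 4 (beyond the scatter) but only a number 2 percentage points lower from compound 2 to compound 4 (within the scatter), so compound 2 goes against any general link between carboxy and a higher number in this small set.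

The compounds shown leave open how an amine or a longer chain on the amide-type nitrogen would read in this assay. Among these compounds, they also leave open how much of the step seen with compound 1 would recur on other cores, and they give no potency for any compound.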